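A few compounds are considered here, and "the series" means these few. Any claim that something is new, unique, unknown or untested is made for them only; others in the source may bear on it.

Measured compounds in a functional assay on DU-145 cells (Homo sapiens) for inhibition, read by trypan blue exclusion, with a stated time of 96 h; on this read-out lower numbers stand for stronger inhibition of growth and higher numbers for weaker inhibition of growth:
- compound 1 `COc1cc(OC)c(/C=C(\C(=O)c2ccc(Br)cc2)S(=O)(=O)c2ccc(Br)cc2)c(OC)c1`: in this assay compound 1 gives only a limit, > 100000 nM.
- compound 2 `O=C(/C(=C\c1c[nH]c2ccccc12)Sc1ccc(Br)cc1)c1ccc(Br)cc1`: compound 2 gives 1000 nM.
- compound 3 `COc1ccc(/C=C(\C(=O)c2ccc(Br)cc2)S(=O)(=O)c2ccc(Br)cc2)c(OC)c1`: compound 3 gives 8000 nM.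

Compound 2 holds the lower of the two plain numbers; its gap to compound 3 lies beyond the scatter, and the difference between the two cores is not broken down here. Within the core of compound 3, the change methoxy in place of hydrogen on an aromatic carbon produces an at least 12-fold higher number from compound 3 to compound 1 (1.09 log units; beyond the scatter); compound 1 sits at the limit of > 100000 nM in this assay, at which 1 of the 3 values shown sits.

Compound 4 `COc1ccc2[nH]cc(/C=C(/Sc3ccc(Br)cc3)C(=O)c3ccc(Br)cc3)c2c1` is not yet measured. It carries the same kind of change as compound 1, (methoxy in place of hydrogen on an aromatic carbon), but the place differs: on compound 1 the methoxy stands ortho to a large group and meta to two methoxy groups, whereas on compound 4 it stands on a six-membered aromatic ring of carbon only, part of a fused or bridged system of two rings, meta to a fused ring and para to a fused ring. Within the data shown here, the only measured instance of this change is the large weakening from compound 3 to compound 1, so a weakening is expected for compound 4 too, though a smaller one given the different surroundings; the expected step is a 3.0-fold higher number from compound 2 to compound 4 (0.48 log units; beyond the scatter). Compound 4 is estimated at 3000 nM, between 800 nM and 12000 nM.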

Compound 4, concentration for 50% growth inhibition: 10000 nM
Estimate against measurement, compound 4: 3.3-fold (0.52 log units) below; measured number inside the range.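

In this assay, methoxy in place of hydrogen on an aromatic carbon weakens growth inhibition on the core of compound 2, giving a 10-fold higher number from compound 2 to compound 4 (1.00 log units; beyond the scatter). Both instances of this change point the same way, but they stand at different places on different cores, so two instances set no rule for the series, and whether their sizes differ remains unsettled: the same change on two cores in this assay, an at least 12-fold higher number (1.09 log units; beyond the scatter) from compound 3 to compound 1 and a 10-fold higher number (1.00 log units; beyond the scatter) from compound 2 to compound 4; the limit leaves it open whether they differ
Compound 1 gives > 100000 nM, which is a limit of the assay and not a number.

Still open, as far as these compounds go, is whether a hydroxyl, a fluorine or an amine on the same carbon of the core of compound 2 would move the number in the same direction as methoxy, or whether the weakening is particular to methoxy. Also open is how far the size of the step depends on its place on the ring, since the compounds shown do not separate that place from the change of core.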